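The source may hold more compounds than are shown below. What is called first, only, known or untested is meant among the compounds shown, and "the series" means these compounds.

Compound 1 `COc1ccc(CN(C(=O)Nc2ccc(F)c(Cl)c2)n2cnnc2)cc1OC` is one of three measured compounds sharing a common core; in a functional assay on MDA-MB-231 cells (Homo sapiens) for cytotoxicity, read by MTT assay, with a stated time of 48 h (on this read-out higher numbers stand for weaker inhibition and lower numbers for stronger inhibition), compound 1 gives 27900 nM. Compound 2 `COc1cc(CN(C(=O)Nc2cc(C(F)(F)F)cc(C(F)(F)F)c2)n2cnnc2)cc(OC)c1OC` gives 24900 nM in this assay, a number within the usual scatter of that of compound 1. Compound 3 `N#Cc1ccc(CN(C(=O)Nc2ccccc2)n2cnnc2)cc1` reaches only a limit of this assay, > 50000 nM, so no number is known for it (the limit of > 50000 nM in this assay, at which 1 of the 3 values shown sits). Compound 4 `CCc1ccc(NC(=O)N(Cc2ccc(OC)c(OC)c2)n2cnnc2)cc1` differs from compound 1 in one place: 4-ethylphenyl in place of 3-chloro-4-fluorophenyl on an amide-type nitrogen. No step of this kind has been measured among these compounds, so the expectation rests on the weak inhibition seen throughout. The step from compound 1 to compound 4 in this assay is expected to be a 1.4-fold higher number from compound 1 to compound 4 (0.13 log units; within the scatter), a modest move toward weaker inhibition. Compound 4 is estimated at 38000 nM, with a range from 13000 nM to 110000 nM.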

Compound 4, half-maximal inhibitory concentration: > 50000 nM
Compound 4 gave a limit, no number (the forecaster's own chance of this, stated with the estimate: 35%); middle value at least 1.3-fold (0.11 log units) from the limit.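

Compound 4 sits at a limit of this assay, > 50000 nM, which is not a number. Even so, it gives the first step measured at this position: replacing 3-chloro-4-fluorophenyl with 4-ethylphenyl on the amide-type nitrogen gives an at least 1.7-fold higher number from compound 1 to compound 4 (0.25 log units; that floor lies within the scatter), so this change shows no gain in inhibition and may weaken it. Limit readings now make up a larger share of the series: the limit of > 50000 nM in this assay, at which 2 of the 4 values shown sit.

On these data alone, the true size of this step remains unknown. Also open, as far as these compounds go, is how the assay would read with an amine or a carboxylic acid in place of the ethyl group.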